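A few compounds are considered here, and "the series" means these few. Any claim that something is new, unique, unknown or untested is made for them only; others in the source may bear on it.

In an ADME assay on Raji cells (Homo sapiens) for cytotoxicity, read by CellTiter-Glo and resazurin assay, with a stated time of 72 h (a lower number here means that less compound is needed, a higher number that more compound is needed for the effect), three compounds have been measured so far:

compound 1 `CC(C)N(Cc1cccc(OCCCCCC(=O)O)c1)C(=O)c1ccc(-c2cccc(N(C)C)c2)cc1`, for which compound 1 gives > 26000 nM, a limit of the assay;
compound 2 `CC(C)N(Cc1cccc(OCCCCCC(=O)O)c1)C(=O)c1ccc(-c2cccc(-c3ccccc3)c2)cc1`, for which compound 2 gives > 26000 nM, a limit of the assay;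
compound 3 `CC(C)N(Cc1cccc(OCCCCCC(=O)O)c1)C(=O)c1ccc(-c2ccoc2)cc1`, for which compound 3 gives > 26000 nM, a limit of the assay.

Compound 3 therefore stands at the limit of this assay, and it is not alone there: the limit of > 26000 nM in this assay, at which 3 of the 3 values shown sit. The steps that connect the three measured compounds are accordingly all unreadable. The step that the two limits leave unreadable from compound 1 to compound 2 cannot be sized, nor can a step that the two limits leave unreadable from compound 1 to compound 3, nor a step that the two limits leave unreadable from compound 2 to compound 3. None of them tells whether a change of the aryl group on the shared core moves the read-out at all.

The next compound, compound 4 `Cc1nnc(-c2cccc(-c3ccc(C(=O)N(Cc4cccc(OCCCCCC(=O)O)c4)C(C)C)cc3)c2)o1`, differs from compound 3 in a single place: 3-(5-methyl-1,3,4-oxadiazol-2-yl)phenyl in place of furan-3-yl on an aromatic carbon. The measured steps that bear on this change are the three unreadable ones above, so they give no direction and no size to expect in this assay. Since every measured compound sits at the limit, compound 4 is expected to sit at the limit as well, so the step that the limit leaves unreadable from compound 3 to compound 4 is estimated to be unreadable. Compound 4 is therefore estimated at 30000 nM, with a range from 10000 nM to 100000 nM.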

Compound 4, half-maximal effective concentration: > 26000 nM
Compound 4 ended at the assay's limit; the forecaster's own chance of this, stated with the estimate: 80%; the middle value is on the limit's open side.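

In this assay compound 4 gives > 26000 nM, which is a limit of the assay, so its steps from compound 1, compound 2 and compound 3 cannot be read. All four compounds share one ceiling: the limit of > 26000 nM in this assay, at which 4 of the 4 values shown sit.

The compounds shown leave open whether changing the aryl group on the shared core moves the read-out at all.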